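Dimethoxyphenyl series: methyl at the ring position

The source may hold more compounds than are shown below. What is called first, only, known or untested is meant among the compounds shown, and "the series" means these compounds.

Measured so far:
compound 1, `COCc1cc(OC)c(-c2cccc3c(N(CC4CCOCC4)CC4CC4)c(C)nn23)c(OC)c1`, 120 nM
compound 2, `CCc1nn2c(-c3c(OC)cccc3OC)cccc2c1N(CC1CCOCC1)CC1CC1`, 105 nM
compound 3, `CCCN(CC1CCOCC1)c1c(CC)nn2c(-c3c(OC)cc(COC)cc3OC)cccc12`, 90 nM

All three numbers come from an assay on HEK293 cells for displacement of a labelled ligand from corticotropin-releasing factor receptor 1 (Homo sapiens), read by scintillation counting, with a stated time of 2 h; on this read-out higher numbers stand for weaker inhibition and lower numbers for stronger inhibition. Compound 2 sits between compound 1 and compound 3, and both gaps lie within the scatter of the read-out; the three compounds are not separated by this assay.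

Compound 4, `CCc1nn2c(-c3c(OC)cc(C)cc3OC)cccc2c1N(CC1CCOCC1)CC1CC1`, has not yet been measured in this assay. It differs from compound 2 by methyl in place of hydrogen on an aromatic carbon. Among the measured compounds shown here, no measured pair shows this change on its own. Since compound 1 and compound 3, which carry a larger group at the same ring position, give numbers indistinguishable from compound 2, the step of a 1.1-fold lower number from compound 2 to compound 4 (0.04 log units; within the scatter) is expected to be none beyond the scatter. Compound 4 is therefore estimated at 95 nM, with a range of 45 nM to 200 nM.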

Compound 4, half-maximal inhibitory concentration: 22 nM
Beside the measured number, compound 4's estimate is 4.3-fold (0.64 log units) above it; measured number below the stated range.
By their numbers in this assay, from the lowest: compound 4; then compounds 3, 2 and 1 (each within the scatter of the next).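

Methyl alone on the aromatic carbon para to a large group moves the number in this assay (a 4.8-fold lower number from compound 2 to compound 4 (0.68 log units; beyond the scatter)). Compound 1 and compound 3 each differ from compound 2 in more than one place, so neither could isolate this change. No measurement shown accounts for the step.

From the compounds shown here alone, whether the step is particular to methyl stays open: an ethyl group, a chlorine atom or an amine on this carbon would test that. Also open, going by these compounds, is whether methyl gives a similar step when the other substituents on the shared core change.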